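From acetyl to methoxycarbonyl on a shared core

The source may hold more compounds than are shown below. What is called first, only, known or untested is meant among the compounds shown, and "the series" means these compounds.

In a functional assay for inhibition, with Homo sapiens as the target (on this read-out higher numbers stand for weaker inhibition and lower numbers for stronger inhibition), compound 1 `CC(C)(O)c1cc(-c2ccccc2)c2ccc(OCc3cccc(C4(O)CCOCC4)c3)cc2c1` gives 59 nM, compound 2 `COCc1cc(-c2ccccc2)c2ccc(OCc3cccc(C4(O)CCOCC4)c3)cc2c1` gives 4 nM and compound 3 `CC(=O)c1cc(-c2ccccc2)c2ccc(OCc3cccc(C4(O)CCOCC4)c3)cc2c1` gives 2 nM. These three share a core and differ in one group. The measured step of a 2.0-fold lower number from compound 2 to compound 3 (0.30 log units; within the scatter) lies within the scatter, so compound 3 stands level with its nearest neighbour. Far larger are the steps of a 15-fold lower number from compound 1 to compound 2 (1.17 log units; beyond the scatter) and a 30-fold lower number from compound 1 to compound 3 (1.47 log units; beyond the scatter).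

Compound 4 `COC(=O)c1cc(-c2ccccc2)c2ccc(OCc3cccc(C4(O)CCOCC4)c3)cc2c1` alters compound 3 in one place: methoxy in place of methyl on a carbonyl carbon. This puts methoxy in place of methyl on a carbonyl carbon, turning acetyl into methoxycarbonyl. Among the compounds with values here, no measured step shows this exact change. The closest guide is the swap of methoxymethyl for acetyl, a 2.0-fold lower number from compound 2 to compound 3 (0.30 log units; within the scatter), which stayed within the scatter. Within the data shown here, compound 4 also lacks the 1-hydroxy-1-methylethyl group, the one group whose replacement gave large steps. The estimated step is a 1.5-fold higher number from compound 3 to compound 4 (0.18 log units; within the scatter), so no change beyond the scatter is expected in this assay. The expected value for compound 4 is 3 nM, with an estimated range of 1 nM to 12 nM.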

Compound 4, half-maximal inhibitory concentration: 3 nM
Compound 4: the middle estimate sits on the measured number at the digits printed, within the range that was stated.
By their numbers in this assay, from the lowest: compounds 3, 4 and 2 (each within the scatter of the next); then compound 1.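

In this assay, the new result adds a third group to the level shared at this aromatic carbon: methoxy in place of methyl on the carbonyl carbon gives a 1.5-fold higher number from compound 3 to compound 4 (0.18 log units; within the scatter), and the comparison with the ether-containing methoxymethyl group gives a 1.3-fold lower number from compound 2 to compound 4 (0.12 log units; within the scatter). Against that close cluster, the 1-hydroxy-1-methylethyl group remains the one clear outlier among the four groups, now also with a 20-fold lower number from compound 1 to compound 4 (1.29 log units; beyond the scatter). Nothing available here explains why acetyl, methoxymethyl and methoxycarbonyl read alike.

Still open, from the compounds shown here alone, is how a carboxylic acid, a primary amide or an amine would read at this aromatic carbon. Hydroxymethyl and isopropyl groups would also help show whether the hydroxyl or the two methyl groups set compound 1 apart.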